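The source may report more compounds than this note shows. Statements on the series, on what has been measured and on what is new or still open speak of the compounds shown alone.

Measured so far:
- compound 1 `Cn1c(=O)c(S(=O)(=O)c2ccc(F)cc2F)cc2cnc(Nc3ccc4sccc4c3)nc21`: 500 nM
- compound 2 `O=c1[nH]c2nc(Nc3ccc4[nH]ccc4c3)ncc2cc1S(=O)(=O)c1ccc(F)cc1F`: 15000 nM

In a functional assay on DU-145 cells (Homo sapiens) for inhibition, read by trypan blue exclusion, with a stated time of 72 h (a lower number here means a stronger inhibitor, a higher number a weaker inhibitor), compound 1 gives the lowest of the two numbers; compound 2 gives a higher number, a gap beyond the usual scatter. Compound 3 `Cn1c(=O)c(S(=O)(=O)c2ccc(F)cc2F)cc2cnc(NCc3ccc4[nH]ccc4c3)nc21` has not yet been measured. It differs from compound 1 in one place: (1H-indol-5-yl)methyl in place of 1-benzothiophen-5-yl on a nitrogen on an aromatic ring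

Within the data shown here, no measured pair shows this single change on its own, so the size of its effect is unknown. The step from compound 1 to compound 3 is expected to weaken inhibition by a moderate amount, a 5.0-fold higher number from compound 1 to compound 3 (0.70 log units; beyond the scatter), since compound 2, which also carries the indole, gives 15000 nM. Compound 3 is therefore estimated at 2500 nM, in the range 600 nM to 10000 nM.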

Compound 3, half-maximal inhibitory concentration: 100000 nM
The estimate for compound 3 lay 40-fold (1.60 log units) below the measured number, outside the stated range (above it).
By their numbers in this assay, from the lowest: compound 1; then compound 2; then compound 3.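

Among these compounds, this is the first single change seen at this position, and in this assay it costs a great deal: putting (1H-indol-5-yl)methyl in place of 1-benzothiophen-5-yl on the nitrogen gives a 200-fold higher number from compound 1 to compound 3 (2.30 log units; beyond the scatter). Inhibition at this position therefore depends strongly on the group carried by that nitrogen. Nothing available explains the size of this loss.

Going by these compounds, the change swaps the ring system and adds a carbon at once, so their separate contributions remain open. A (1-benzothiophen-5-yl)methyl group on the core of compound 1 would help separate them.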